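The compounds below may be only part of what the source reports. "The series", "measured", "known", "first", "only" and "open" are said of these compounds alone.

Compound 1 `c1ccc(CNCc2cn(Cc3ccccc3)c3ccccc23)cc1`, compound 2 `CC#CCN(C)Cc1cc2cc(O)ccc2n1C` and compound 3 `C#CCNCc1cc2ccccc2n1C` were each tested in an assay on isolated protein for inhibition of Amine oxidase [flavin-containing] A (Rattus norvegicus); on this read-out higher numbers stand for weaker inhibition and lower numbers for stronger inhibition. Compound 1 gives 245000 nM, compound 2 gives 5.75 nM and compound 3 gives 240 nM. Compound 3 therefore stands second highest of the three: its number lies far below that of compound 1 and well above that of compound 2, both gaps beyond the scatter. Compound 4 `C#CCN(Cc1ccccc1)Cc1cc2ccccc2n1C` has not yet been measured. It differs from compound 3 in one place: benzyl in place of hydrogen on an amine nitrogen. Among the measured compounds shown here, no measured pair shows this exact change, so any expectation is loose; a modest rise in the number is expected, a 2.5-fold higher number from compound 3 to compound 4 (0.40 log units; beyond the scatter), because compound 3 already sits at 240 nM and the added group is large. Compound 4 is expected at 600 nM, between 150 nM and 2500 nM.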

Compound 4, inhibition constant: 10000 nM
Beside the measured number, compound 4's estimate is 17-fold (1.22 log units) below it; the whole stated range lies below it.
By their numbers in this assay, from the lowest: compound 2; then compound 3; then compound 4; then compound 1.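

In this assay, among the compounds shown here, benzyl in place of hydrogen on this amine nitrogen gives a 42-fold higher number from compound 3 to compound 4 (1.62 log units; beyond the scatter), the first change at this position that can be read on its own. A large step of this kind shows that the number here depends strongly on what this nitrogen carries. Nothing at hand explains why the step is so large. Still open, going by these compounds, is whether a smaller group such as ethyl would leave the number close to that of compound 3. On these data alone, a phenethyl group, with a longer chain to its ring, also remains open.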